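The compounds below may be only part of what the source reports. "The series", "measured", "known", "first", "only" and "open" are said of these compounds alone.

Three measured compounds share one core and differ only in the group carried on an amine nitrogen in a ring. Compound 1 `O=C(c1ccc(C(F)(F)F)cc1)N1CCC(NS(=O)(=O)c2cc(S(=O)(=O)c3ccccc3)ccc2C(F)(F)F)CC1` gives 400 nM in an assay on isolated protein for displacement of a labelled ligand from secreted frizzled-related protein 1 (Homo sapiens), read by fluorescence polarization, with a stated time of 30 min; a higher number here means a weaker inhibitor, a lower number a stronger inhibitor. Compound 2 `N#Cc1cccc(S(=O)(=O)N2CCC(NS(=O)(=O)c3cc(S(=O)(=O)c4ccccc4)ccc3C(F)(F)F)CC2)c1` gives 90 nM in this assay. Compound 3 `O=C(C1CCNCC1)N1CCC(NS(=O)(=O)c2cc(S(=O)(=O)c3ccccc3)ccc2C(F)(F)F)CC1` gives 120 nM in this assay. Among these three numbers compound 3 stands second highest: its nearest neighbour is compound 2, and the gap between them, a 1.3-fold higher number from compound 2 to compound 3 (0.12 log units; within the scatter), is within the scatter; its furthest is compound 1, and that gap, a 3.3-fold lower number from compound 1 to compound 3 (0.52 log units; beyond the scatter), is beyond the scatter.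

Compound 4 `O=C([C@H]1CCNC1)N1CCC(NS(=O)(=O)c2cc(S(=O)(=O)c3ccccc3)ccc2C(F)(F)F)CC1` is not yet measured. Its change from compound 3 is pyrrolidin-3-yl in place of piperidin-4-yl on a carbonyl carbon. Both earlier steps swap the whole group on the amine nitrogen, with the amide-type nitrogen in a ring kept, and they range from the modest 3.3-fold lower number from compound 1 to compound 3 (0.52 log units; beyond the scatter) to the flat a 1.3-fold higher number from compound 2 to compound 3 (0.12 log units; within the scatter). Going from one small saturated ring to another is a lesser change than either, so no step beyond the scatter is expected, and compound 4 is estimated at 120 nM in this assay, within a range of 50 nM to 300 nM, which means an expected step of no change at the digits printed from compound 3 to compound 4 (within the scatter).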

Compound 4, half-maximal inhibitory concentration: 40 nM
For compound 4 the middle estimate is 3.0-fold (0.48 log units) above the measured one; measured number outside the range, below it.
By their numbers in this assay, from the lowest: compound 4; then compounds 2 and 3 (each within the scatter of the next); then compound 1.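

Going from piperidin-4-yl to pyrrolidin-3-yl on the carbonyl carbon is not a silent change in this assay: it gives a 3.0-fold lower number from compound 3 to compound 4 (0.48 log units; beyond the scatter) and shows that this position responds to a swap between two small saturated rings, whereas the earlier steps exchanged the whole group on the ring nitrogen. Compound 4 also separates from the sulfonyl compound, with a 2.3-fold lower number from compound 2 to compound 4 (0.35 log units; beyond the scatter) where compound 3 had stayed within the scatter of it, and a 10-fold lower number from compound 1 to compound 4 (1.00 log units; beyond the scatter) makes it the strongest inhibitor of the four. Nothing available explains why the smaller ring gives the lower number.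

The step changes ring size and adds a defined stereocentre together, so the compounds shown do not separate the two. Also open, on these data alone, is how the opposite stereoisomer of pyrrolidin-3-yl, or an azetidin-3-yl ring on the same carbonyl carbon, would read in this assay and whether the trend continues.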